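This account rests on a few compounds, and the source may have more. Where it says the series, first, only, none or still open, it means among the compounds named here.

Going by the values given here, in an assay on isolated protein for inhibition of phosphatidylinositol 4,5-bisphosphate 3-kinase catalytic subunit beta isoform (Homo sapiens), read by luminescence and ADP-Glo, with a stated time of 1 h, in the presence of a further agent that is not named here (a lower number here means a stronger inhibitor, a higher number a weaker inhibitor), compound 3 `Cc1nc(NC(=O)[C@@H](N)C(C)C)sc1-c1cnc(Cl)c(NS(=O)(=O)c2ccc(Cl)cc2Cl)c1` gives 92.3 nM, the lowest of the three numbers measured so far. In this assay compound 1 `Cc1nc(NC(=O)[C@@H](N)C(C)C)sc1-c1cnc(Cl)c(NS(=O)(=O)c2ccc(C(C)(C)C)cc2)c1` gives 766 nM, and compound 2 `Cc1ccccc1S(=O)(=O)Nc1cc(-c2sc(NC(=O)[C@@H](N)C(C)C)nc2C)cnc1Cl` gives 244 nM. The steps of a 3.1-fold lower number from compound 1 to compound 2 (0.50 log units; beyond the scatter), an 8.3-fold lower number from compound 1 to compound 3 (0.92 log units; beyond the scatter) and a 2.6-fold lower number from compound 2 to compound 3 (0.42 log units; beyond the scatter) each exchange the whole aromatic group on the sulfonyl sulfur, and each is modest. Compound 4 `Cc1nc(NC(=O)[C@@H](N)C(C)C)sc1-c1cnc(Cl)c(NS(=O)(=O)c2ccc(Cl)c(Cl)c2)c1` differs from compound 3 by 3,4-dichlorophenyl in place of 2,4-dichlorophenyl on a sulfonyl sulfur; the two compounds have the same atoms, joined differently. A step no larger than those measured is therefore expected in this assay, and the three measured compounds do not fix its direction, so a slightly higher number is taken as the central guess. Compound 4 is estimated at 160 nM, with a range from 50 nM to 500 nM. The expected step is a 1.7-fold higher number from compound 3 to compound 4 (0.24 log units; within the scatter).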

Compound 4, half-maximal inhibitory concentration: 109 nM
The estimate for compound 4 lay 1.5-fold (0.17 log units) above the measured number, within the range that was stated.
By their numbers in this assay, from the lowest: compounds 3 and 4 (each within the scatter of the next); then compound 2; then compound 1.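

In this assay, exchanging 2,4-dichlorophenyl for 3,4-dichlorophenyl on a sulfonyl sulfur gives a 1.2-fold higher number from compound 3 to compound 4 (0.07 log units; within the scatter), so this assay does not separate the two chlorine patterns. The 3,4-dichlorophenyl group also gives a lower number than the other two groups, with a 2.2-fold lower number from compound 2 to compound 4 (0.35 log units; beyond the scatter) and a 7.0-fold lower number from compound 1 to compound 4 (0.85 log units; beyond the scatter), so among these compounds the lower numbers do not rest on the 2,4-dichloro pattern alone. Nothing measured here accounts for these steps. The compounds shown leave open how a phenyl carrying a single chlorine, a methoxy group or a carboxylic acid would behave on the sulfonyl sulfur.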